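Chloro in place of bromo across two cores

A few compounds are considered here, and "the series" means these few. Any claim that something is new, unique, unknown or untested is made for them only; others in the source may bear on it.

Compound 1 `Cc1nc(C)c(-c2nn(-c3ccc(F)cc3)cc2/C=C/C(=O)c2cc(Br)ccc2O)s1`: in an ADME assay on PANC-1 cells (Homo sapiens) for inhibition, read by MTT assay (a lower number here means a stronger inhibitor of growth, a higher number a weaker inhibitor of growth), compound 1 gives > 250 ug/mL, a limit of the assay.
Compound 2 `Cc1nc(C)c(-c2nn(-c3ccc(F)cc3)cc2/C=C/C(=O)c2cc(Cl)ccc2O)s1`: in this assay compound 2 gives > 250 ug/mL, likewise a limit.
Among the compounds with values here, compound 3 `Cc1nc(C)c(-c2nn(-c3ccc(F)cc3)cc2C2CC(c3cc(Br)ccc3O)=NN2)s1`: in this assay compound 3 gives 76.4 ug/mL, the only number in the set.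

The change chloro in place of bromo on an aromatic carbon gives the step that the two limits leave unreadable from compound 1 to compound 2, which cannot be read because both ends rest at the limit of > 250 ug/mL in this assay, at which 2 of the 3 values shown sit. The difference between the core of compound 1 and the core of compound 3 is not broken down here.

Compound 4 `Cc1nc(C)c(-c2nn(-c3ccc(F)cc3)cc2C2CC(c3cc(Cl)ccc3O)=NN2)s1` is not yet measured; it differs from compound 3 by chloro in place of bromo on an aromatic carbon, the same change as above on the same place. With no readable size for that change, the step of a 1.0-fold lower number from compound 3 to compound 4 (0.00 log units; within the scatter) is expected to be small, resting on compound 3 at 76.4 ug/mL. Compound 4 is thus estimated at 76 ug/mL, between 35 ug/mL and 170 ug/mL.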

Compound 4, concentration for 50% growth inhibition: > 250 ug/mL
Compound 4: only a limit was reported; the forecaster's own chance of this, stated with the estimate: 15%; middle value at least 3.2-fold (0.51 log units) away from the limit.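

In this assay, chloro in place of bromo on the core of compound 3 gives an at least 3.2-fold higher number from compound 3 to compound 4 (0.51 log units; beyond the scatter), so on this core the change is not silent. From the compounds shown here alone, compound 4 gives a limit, not a number, and the true size of the step remains unknown: the limit of > 250 ug/mL in this assay, at which 3 of the 4 values shown sit. The step from compound 1 to compound 2 cannot be read, so this set does not show whether the change behaves alike on the two cores.

Within the data shown here, compound 3 is the only compound here with a number, which leaves open whether that number depends on bromo specifically. A methoxy, an amine or a carboxylic acid in the same place on the core of compound 3 remains untested in the compounds shown.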